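Cytotoxicity of a benzyl-imidazole series on mouse fibroblasts

The source may report more compounds than this note shows. Statements on the series, on what has been measured and on what is new or still open speak of the compounds shown alone.

The series shares one core, carried by compound 1 `COC(=O)c1ccc(NCc2cncn2Cc2ccc(C(C)(C)C)cc2)cc1-c1ccccc1` and compound 2 `COC(=O)c1ccc(NCc2cncn2Cc2cccc(-c3ccccc3)c2)cc1-c1ccccc1`, for which in a toxicity assay on NIH3T3 cells (Mus musculus) for cytotoxicity, read by resazurin assay (on this read-out higher numbers stand for an effect only at larger amounts of compound and lower numbers for an effect already at smaller amounts), compound 1 shows "not determined" (no result reported) and compound 2 shows "not determined" (no result reported). Only compound 3 `COC(=O)c1ccc(NCc2cncn2Cc2ccccc2Br)cc1-c1ccccc1` has a number: in this assay compound 3 gives 10000 nM, so it stands alone as the single measured point of the set. Compound 4 `COC(=O)c1ccc(NCc2cncn2Cc2cccc(N)c2)cc1-c1ccccc1` is not yet measured. It differs from compound 3 by 3-aminophenyl in place of 2-bromophenyl on a saturated chain carbon bound to an aromatic nitrogen. Among the compounds with values here, with no step between measured compounds available, the expected change from compound 3 to compound 4 in this assay is a 1.2-fold higher number from compound 3 to compound 4 (0.08 log units; within the scatter), which lies within the usual scatter. Compound 4 is therefore estimated at 12000 nM, within a range of 5000 nM to 30000 nM.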

Compound 4, half-maximal effective concentration: > 10000 nM
Compound 4 was reported as a limit; the forecaster's own chance of this, stated with the estimate: 30%; the middle value lies beyond the limit too.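

The series now has its first comparison: in this assay, replacing 2-bromobenzyl with 3-aminobenzyl on a saturated chain carbon bound to an aromatic nitrogen gives a number no lower from compound 3 to compound 4 (the limit leaves the size open). For compound 4 the result is a limit, not a number: the limit of > 10000 nM in this assay, at which 1 of the 4 values shown sits. This place therefore tolerated this exchange without a lower number, which a single measured compound could not show.

The compounds shown leave open how 2-aminophenyl or 3-hydroxyphenyl would read here. They also cannot separate the exchange of bromine for an amine from the different ring position.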